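A few compounds are considered here, and "the series" means these few. Any claim that something is new, unique, unknown or untested is made for them only; others in the source may bear on it.

Among the measured compounds shown here, in an assay on isolated protein for displacement of a labelled ligand from metabotropic glutamate receptor 5 (Homo sapiens), with a stated time of 60 min, tested at 1 uM (on this read-out higher numbers stand for more inhibition at the one concentration tested (going by the name of the read-out) and lower numbers for less inhibition), compound 1, `CC1CCN(c2c(S(=O)(=O)c3ccc(Cl)cc3)cnc3cc(Cl)ccc23)CC1`, gives 91%, the highest of the three numbers known here. Compound 2, `CC1CCN(c2c(S(=O)(=O)c3ccc(Cl)cc3)cnc3cc(F)ccc23)CC1`, gives 90%; the step of a number 1 percentage points lower from compound 1 to compound 2 (within the scatter) comes from fluoro in place of chloro on an aromatic carbon. Compound 3, `NS(=O)(=O)N1CCN(c2c(S(=O)(=O)c3cccc(F)c3)cnc3cc(F)ccc23)CC1`, gives 1.9%, far lower. Compound 4, `COc1ccc(S(=O)(=O)c2cnc3cc(Cl)ccc3c2N2CCC(C)CC2)cc1`, has not been measured; it differs from compound 1 by methoxy in place of chloro on an aromatic carbon. For the measured compounds named here, no measured step replaces chloro with methoxy, so the only guide is the halogen exchange from compound 1 to compound 2, which stayed within the scatter and alters a different part of the molecule. A step of a number 7 percentage points lower from compound 1 to compound 4 (within the scatter) is therefore expected, likely no larger than the scatter. Compound 4 is estimated at 84%, between 55% and 97%.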

Compound 4, a percentage reported as inhibition, at one concentration (the size of the read-out at that concentration, not a potency): 79%
Beside the measured number, compound 4's estimate is 5 percentage points above it; the range from low to high includes it.
By their numbers in this assay, from the lowest: compound 3; then compound 4; then compounds 2 and 1 (each within the scatter of the next).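

Going from 4-chlorophenyl to 4-methoxyphenyl gives a number 12 percentage points lower from compound 1 to compound 4 (beyond the scatter) in this assay and is the only single change shown at this position. It shows that the group para to the large group matters to the read-out, since this step lies beyond the scatter, yet compound 4 still gives 79% and keeps much of the inhibition. Nothing here explains why the number falls.

As far as these compounds go, whether an amine, a carboxylic acid or a longer chain such as ethoxy at this position would keep the inhibition stays open. So does whether methoxy would give a similar step with fluoro rather than chloro on the shared core.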